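Imidazoline to imidazolyl sulfanyl on a sulfonamide phenyl

This account rests on a few compounds, and the source may have more. Where it says the series, first, only, none or still open, it means among the compounds named here.

Three structures appear here: compound 1 `Oc1cccc2c1CCCC2c1c[nH]cn1`, compound 2 `CCS(=O)(=O)Nc1cccc(NC2=NCCN2)c1` and compound 3 `CCS(=O)(=O)Nc1cccc(Sc2c[nH]cn2)c1`. In an assay on isolated protein (Cricetulus griseus) for binding affinity to Alpha-1B adrenergic receptor (Mesocricetus auratus), read by radioligand binding (a lower number here means a stronger inhibitor, a higher number a weaker inhibitor), compound 1 gives 145 nM. For compound 2 only a limit is known, < 10000 nM, as the limit of < 10000 nM in this assay, at which 1 of the 2 values shown sits, shows, so no exact number places it. Compound 3 differs from compound 2 by a group of 6 heavy atoms (3 carbon, 2 nitrogen, 1 sulfur; one five-membered aromatic ring with 2 hetero atoms) in place of a group of 6 heavy atoms (3 carbon, 3 nitrogen; one five-membered non-aromatic ring with 2 hetero atoms), on an aromatic carbon. For the measured compounds named here, no measured step of this kind exists to lean on, so a gain of moderate size is expected, a step that the limit leaves unreadable from compound 2 to compound 3, though the limit on compound 2 leaves that step itself uncertain. Compound 3 is therefore expected near 1500 nM, within 150 nM to 10000 nM.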

Compound 3, inhibition constant: < 10000 nM
Compound 3: only a limit was reported; the forecaster's own chance of this, stated with the estimate: 30%; the middle value is on the limit's open side.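

For the compounds shown here, compound 2 and compound 3 each carry only a limit in this assay, not an exact number, so no step between them can be read. From the compounds shown here alone, whether the (1H-imidazol-4-yl)sulfanyl group strengthens or weakens binding stays open.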